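Shifting the Chlorine on the Benzyl Group

The source may report more compounds than this note shows. Statements on the series, on what has been measured and on what is new or still open speak of the compounds shown alone.

Compound 1 `O=c1ccoc2cc(OCc3cn(Cc4ccc(Cl)cc4)nn3)ccc12` was tested in a functional assay on MDA-MB-231 cells (Homo sapiens) for cytotoxicity, read by MTT assay, with a stated time of 48 h; a higher number here means a weaker inhibitor, a lower number a stronger inhibitor. In this assay compound 1 gives only a limit, > 100000 nM, so no number is known for it. Compound 2 `O=c1ccoc2cc(OCc3cn(Cc4cccc(Br)c4)nn3)ccc12` likewise gives only a limit in this assay, > 100000 nM. That step, a step that the two limits leave unreadable from compound 1 to compound 2, cannot be read. Compound 3 `O=c1ccoc2cc(OCc3cn(Cc4ccccc4Cl)nn3)ccc12` differs from compound 1 by 2-chlorophenyl in place of 4-chlorophenyl on a saturated chain carbon bound to an aromatic nitrogen. Going by the values given here, since both values so far sit at the limit (the limit of > 100000 nM in this assay, at which 2 of the 2 values shown sit), no measured step bears on this change, and no direction can be expected beyond the scatter. Compound 3 is expected to give 150000 nM, between 40000 nM and 600000 nM, a step that the limit leaves unreadable from compound 1 to compound 3, most likely once more only a limit.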

Compound 3, half-maximal inhibitory concentration: 15100 nM
For compound 3 the middle estimate is 9.9-fold (1.00 log units) above the measured one, outside the stated range (below it).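

Among the compounds shown, only the 2-chlorobenzyl group brings a measurable value in this assay, so with the same atoms joined differently, where the halogen sits on the ring matters. Moving the chlorine gives an at least 6.6-fold lower number from compound 1 to compound 3 (0.82 log units; beyond the scatter), and the swap from 3-bromophenyl gives an at least 6.6-fold lower number from compound 2 to compound 3 (0.82 log units; beyond the scatter). Both sizes are only minimum sizes, because the starting compounds give no number: the limit of > 100000 nM in this assay, at which 2 of the 3 values shown sit.

The second step changes both the halogen and its place, so their shares cannot be separated. On these data alone, whether 2-bromophenyl, 2-methylphenyl or 2-methoxyphenyl would act like 2-chlorophenyl remains open.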